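Dropping the Bromine and Methyl: A Smaller Fluorinated Aryl Amide

This account rests on a few compounds, and the source may have more. Where it says the series, first, only, none or still open, it means among the compounds named here.

Of the compounds shown here, two with a shared core have been measured in a functional assay on HEK293 cells for agonist activity at D(4) dopamine receptor (Homo sapiens), read by FLIPR; on this read-out higher numbers stand for larger maximal responses and lower numbers for smaller maximal responses. Compound 1 `O=C(CN1CCC(c2cccc[n+]2[O-])CC1)Nc1ccc(F)cc1F` carries a 2,4-difluorophenyl group on the amide nitrogen, and in this assay compound 1 gives 74%. Compound 2 `Cc1cc(Br)ccc1NC(=O)CN1CCC(c2cccc[n+]2[O-])CC1` carries a 4-bromo-2-methylphenyl group at the same place, and in this assay compound 2 gives 61%. Between the two there is a number 13 percentage points lower from compound 1 to compound 2 (beyond the scatter). Within the data shown here, on the numbers so far, compound 2 stands lowest of the two, with compound 1 as its nearest neighbour.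

Compound 3 `O=C(CN1CCC(c2cccc[n+]2[O-])CC1)Nc1ccccc1F` is not yet measured. It differs from compound 2 in one place: 2-fluorophenyl in place of 4-bromo-2-methylphenyl on an amide-type nitrogen. Among the measured compounds shown here, the only measured step that bears on this exchange of the aryl group is the one from compound 1 to compound 2, which was modest. Because that step was a number 13 percentage points lower from compound 1 to compound 2 (beyond the scatter), and compound 3 returns to a fluorinated phenyl ring more like compound 1, a modest rise is expected in this assay, a number 9 percentage points higher from compound 2 to compound 3 (within the scatter). The estimate for compound 3 in this assay is 70%, with a range from 55% to 85%.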

Compound 3, largest response reached (reported as efficacy), in percent of the reference or control that the assay uses: 63%
The estimate for compound 3 lay 7 percentage points above the measured number; the range from low to high includes it.
By their numbers in this assay, from the lowest: compounds 2 and 3 (each within the scatter of the next); then compound 1.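

In this assay, putting 2-fluorophenyl in place of 4-bromo-2-methylphenyl on the amide-type nitrogen gives a number 2 percentage points higher from compound 2 to compound 3 (within the scatter), so two aryl groups that differ in their atoms and in their number of heavy atoms cannot be told apart on this read-out. The smallest edit in the set, hydrogen in place of fluoro on an aromatic carbon, gives a number 11 percentage points lower from compound 1 to compound 3 (beyond the scatter), which shows that the maximal response at this position can shift beyond the scatter with the loss of one fluoro, while compound 2 and compound 3 remain level with each other. Among these compounds, nothing available explains why the single fluoro exchange registers here while the exchange of the larger group does not.

From the compounds shown here alone, it remains open whether plain phenyl or 4-fluorophenyl on the amide-type nitrogen would sit with compound 1 or with compound 2 and compound 3, which would show how much each fluoro contributes. The compounds shown also leave open how the response would change with a methoxy group, an amine or a carboxylic acid on the aromatic ring.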